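The source may report more compounds than this note shows. Statements on the series, on what has been measured and on what is new or still open speak of the compounds shown alone.

Measured so far:
compound 1, `Cc1c(OCCCCOCOc2ccc(C(=O)O)cc2)ccc(C(=O)CC2CCCC2)c1O`, 95.4%
compound 2, `Cc1c(OCCCCOc2ccccc2C(=O)O)ccc(C(=O)CC2CCCC2)c1O`, 98.8%

In an assay on HEK293 cells for positive allosteric modulation of metabotropic glutamate receptor 2 (Rattus norvegicus), read by thallium flux, with a stated time of 2.5 min (on this read-out lower numbers stand for smaller maximal responses and higher numbers for larger maximal responses), compound 1 gives 95.4% and compound 2 gives 98.8%. Compound 2 sits side by side with compound 1: the step of a number 3.4 percentage points higher from compound 1 to compound 2 (within the scatter) stays within the scatter, so neither compound is set apart from the other on this assay.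

Compound 3, `Cc1c(OCCCCOc2ccc(C(=O)O)cc2Cl)ccc(C(=O)CC2CCCC2)c1O`, has not been measured. Its change from compound 2 is 4-carboxy-2-chlorophenyl in place of 2-carboxyphenyl on an oxygen on a saturated carbon. Going by the values given here, the only measured step that bears on it is a number 3.4 percentage points higher from compound 1 to compound 2 (within the scatter), which also exchanged the aryl part carried on the same oxygen on a saturated carbon and left this assay essentially unmoved. Among the compounds with values here, with only that step to go on, the expected step of a number 2.8 percentage points lower from compound 2 to compound 3 (within the scatter) is none beyond the scatter. Compound 3 is therefore estimated at 96% in this assay, with a range from 82% to 108%.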

Compound 3, largest response reached (reported as percent of maximum), in percent of the reference or control that the assay uses: 82.2%
Beside the measured number, compound 3's estimate is 13.8 percentage points above it; low and high end bracket the measured number.
By their numbers in this assay, from the lowest: compound 3; then compounds 1 and 2 (each within the scatter of the next).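

On an oxygen on a saturated carbon, the aryl part matters in this assay in a way the earlier pair did not show: 4-carboxy-2-chlorophenyl in place of 2-carboxyphenyl gives a number 16.6 percentage points lower from compound 2 to compound 3 (beyond the scatter) and, in place of (4-carboxyphenoxy)methyl, gives a number 13.2 percentage points lower from compound 1 to compound 3 (beyond the scatter) while those two replaced groups stay within the scatter of each other. Going by these compounds alone, the maximal response at this position therefore does respond to the group carried there, and the one group that sets itself apart is the chlorine-bearing one. Nothing available accounts for this drop.

Compound 3 differs from compound 2 both in its chlorine and in where the carboxylic acid stands on the ring, so the two contributions remain unseparated. A plain 4-carboxyphenyl group would separate them, and a 2-carboxy-4-chlorophenyl group would test the chlorine with the acid kept as in compound 2.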